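The source may report more compounds than this note shows. Statements on the series, on what has been measured and on what is new or still open speak of the compounds shown alone.

Compound 1 `CN1CCc2c(sc(NC(=O)Nc3ccc(Cl)cc3)c2C(N)=O)C1` gives 4700 nM in a functional assay (strain AB) with Danio rerio as the target, read by microscopy, with a stated time of 1 h; on this read-out lower numbers stand for an effect already at smaller amounts and higher numbers for an effect only at larger amounts of compound.
Compound 2 `CCN1CCc2c(sc(NC(=O)NCC3CCCO3)c2C(N)=O)C1` gives > 25000 nM, a limit of the assay rather than a number.
Compound 3 `CC1CCc2nc(NC(=O)Nc3ccc(Cl)cc3)sc2C1` gives > 25000 nM, also a limit of the assay.

Among the compounds with values here, of the three measured compounds, compound 1 is the only one that yields a number in this assay; the other two sit at the limit of > 25000 nM in this assay, at which 2 of the 3 values shown sit, so no measured step links any pair of them and compound 1 stands alone as the reference point. The compound that has not yet been measured, compound 4 `CC(C)(C)OC(=O)CCN1CCc2c(sc(NC(=O)Nc3ccc(Cl)cc3)c2C(N)=O)C1`, differs from compound 1 in one place: (tert-butoxycarbonyl)methyl in place of hydrogen on a saturated chain carbon bound to an amine nitrogen in a ring. The shared core of compound 1 and compound 4 is otherwise unchanged, and the chlorophenyl urea and the carboxamide are kept.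

Within the data shown here, with no measured step available, the expected size of the change from compound 1 to compound 4 in this assay can rest only on the structural change itself. The step of a 1.5-fold higher number from compound 1 to compound 4 (0.17 log units; within the scatter) is expected to be small, toward an effect only at somewhat larger amounts of compound, or none beyond the usual scatter. Compound 4 is therefore estimated at 7000 nM, with a range from 2500 nM to 25000 nM in this assay.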

Compound 4, half-maximal effective concentration: 1100 nM
Estimate against measurement, compound 4: 6.4-fold (0.80 log units) above, outside the stated range (below it).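

In this assay, placing (tert-butoxycarbonyl)methyl in place of hydrogen on a saturated chain carbon bound to an amine nitrogen in a ring gives a 4.3-fold lower number from compound 1 to compound 4 (0.63 log units; beyond the scatter), so this place accepts an addition of 8 heavy atoms without loss of the effect, and the effect appears at smaller amounts of compound. Within the data shown here, the earlier compounds could not show this, as compound 1 alone gave a number and no step linked it to any other compound, while this result supplies the first readable step and the first sign that changes at this place can move the read-out. Nothing measured here accounts for the size of this step.

The compounds shown do not tell whether the tert-butyl ester as a whole matters or the longer chain alone, and a carboxylic acid, an amine or a plain propyl chain at this place would help to separate the two. They also leave open whether the chlorophenyl urea and the carboxamide, kept in both compound 1 and compound 4, are needed for this step.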